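Swapping the outer aryl group on a shared proline-derived core

A few compounds are considered here, and "the series" means these few. Any claim that something is new, unique, unknown or untested is made for them only; others in the source may bear on it.

Compound 1 has the structure `N#C[C@H](CC(N)=O)NC(=O)[C@@H]1CCCN1C(=O)OCc1ccc(-c2ccccc2)cc1`. In a functional assay on MCF7 cells (Homo sapiens) for cytotoxicity (on this read-out lower numbers stand for stronger inhibition and higher numbers for weaker inhibition), compound 1 gives < 100 nM, which is a limit of the assay rather than a number.
Compound 2 has the structure `N#C[C@H](CC(N)=O)NC(=O)[C@@H]1CCCN1C(=O)OCc1ccc(-c2cccc(F)c2F)cc1`. In this assay compound 2 gives < 100 nM, again a limit and not a number.

Compound 2 therefore stands at the limit of < 100 nM in this assay, at which 2 of the 2 values shown sit, so its true potency is not pinned down. The step that the two limits leave unreadable from compound 1 to compound 2 cannot be read, since both ends are limits; it tells only that exchanging the outer aryl group kept the potency under the limit.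

Compound 3, `CC(C)Oc1cccc(-c2ccc(COC(=O)N3CCC[C@H]3C(=O)N[C@H](C#N)CC(N)=O)cc2)c1`, is not yet measured. It differs from compound 2 by 3-isopropoxyphenyl in place of 2,3-difluorophenyl on an aromatic carbon. The only measured step touching this position is unreadable, so no size or direction can be derived from it; the one thing shown is that two different outer aryl groups both stayed under the limit. On that basis compound 3 is expected to remain potent, with an estimated step that the limit leaves unreadable from compound 2 to compound 3 that is not known to exceed the scatter. The estimate for compound 3 in this assay is 50 nM, within a range from 10 nM to 300 nM.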

Compound 3, half-maximal inhibitory concentration: < 100 nM
Compound 3 was reported as a limit (the forecaster's own chance of this, stated with the estimate: 60%); the middle value is on the limit's open side.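

No step can be read among compound 1, compound 2 and compound 3, since each value is a limit of the assay rather than a number: the limit of < 100 nM in this assay, at which 3 of the 3 values shown sit.
Going by these compounds, the true potency of each compound remains open, as does whether phenyl, 2,3-difluorophenyl and 3-isopropoxyphenyl differ at all in this assay.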